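A few compounds are considered here, and "the series" means these few. Any claim that something is new, unique, unknown or untested is made for them only; others in the source may bear on it.

In an assay on HL-60 cells for agonist activity at vitamin D3 receptor (Homo sapiens), read by microscopy, with a stated time of 96 h (a higher number here means that more compound is needed for the effect, a lower number that less compound is needed), compound 1 `CCn1c(C(=O)NCCN(C)C)ccc1C(CC)(CC)c1ccc(OCC(=O)C(C)(C)C)c(C)c1` gives 77 nM, and compound 2 `CCn1c(C(=O)NCCN(C)C)ccc1C(CC)(CC)c1ccc(OCC(O)C(C)(C)C)c(C)c1` gives 14 nM. Going by the values given here, the only measured step, a 5.5-fold lower number from compound 1 to compound 2 (0.74 log units; beyond the scatter), concerns the chain on the ring oxygen. Among the compounds with values here, compound 2 therefore stands lowest of the two numbers, with compound 1 as its single neighbour at a higher value. Compound 3 `CCn1c(C(=O)NCCN)ccc1C(CC)(CC)c1ccc(OCC(O)C(C)(C)C)c(C)c1` is the unmeasured member; it differs from compound 2 by amino in place of dimethylamino on a saturated chain carbon, two bonds along the chain from an amide-type nitrogen. Within the data shown here, no measured step touches the amide side chain, so the step from compound 1 to compound 2 offers no precedent here, and nothing shows what exchanging dimethylamino for amino does. Among the measured compounds shown here, with no bearing step, no shift beyond the scatter is expected, though the absence of precedent widens the range. The step from compound 2 to compound 3 is expected to be a 1.4-fold higher number from compound 2 to compound 3 (0.15 log units; within the scatter). Compound 3 is estimated at 20 nM, within 5 nM to 80 nM.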

Compound 3, half-maximal effective concentration: 10 nM
Estimate against measurement, compound 3: 2.0-fold (0.30 log units) above; low and high end bracket the measured number.
By their numbers in this assay, from the lowest: compounds 3 and 2 (each within the scatter of the next); then compound 1.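

In this assay, going by these compounds alone, amino in place of dimethylamino on a saturated chain carbon, two bonds along the chain from an amide-type nitrogen, gives a 1.4-fold lower number from compound 2 to compound 3 (0.15 log units; within the scatter) and so provides the first reading on the amide side chain, as the earlier step concerned only the chain on the ring oxygen. At this position, dimethylamino can be exchanged for amino with no shift beyond the scatter, so this change does not separate compound 2 from compound 3. No supporting data bear on why the two groups read alike.

Still open, as far as these compounds go, is how a larger amine such as diethylamino or pyrrolidine, a longer chain, or a carboxylic acid in place of the amine would read here. Also open, from the compounds shown here alone, is whether the amino exchange would read the same with the carbonyl of compound 1 on the ring-oxygen chain.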